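Dihydroxypyrimidine sulfonamides with triazole-linked chlorophenyl groups

The compounds below may be only part of what the source reports. "The series", "measured", "known", "first", "only" and "open" are said of these compounds alone.

Compound 1 `O=c1[nH]cc(S(=O)(=O)Nc2ccccc2-c2cn(-c3cccc(Cl)c3)nn2)c(=O)[nH]1` carries a 3-chlorophenyl on the triazole nitrogen. In a functional assay on SGC-7901 cells (Homo sapiens) for antiproliferative activity, read by MTT assay, with a stated time of 24 h (on this read-out lower numbers stand for stronger inhibition and higher numbers for weaker inhibition), compound 1 gives 2270 nM. Compound 2 `O=c1[nH]cc(S(=O)(=O)Nc2ccccc2-c2cn(-c3ccc(Cl)cc3)nn2)c(=O)[nH]1` differs from it in one place: 4-chlorophenyl in place of 3-chlorophenyl on an aromatic nitrogen. In this assay compound 2 gives 2700 nM, and the step of a 1.2-fold higher number from compound 1 to compound 2 (0.08 log units; within the scatter) shows that this exchange leaves the read-out essentially where it was.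

Compound 3 `O=c1[nH]cc(S(=O)(=O)Nc2ccc(-c3cn(-c4cccc(Cl)c4)nn3)cc2)c(=O)[nH]1` keeps the 3-chlorophenyl but carries a different core; the difference between the core of compound 1 and the core of compound 3 is not broken down here. In this assay compound 3 gives 2460 nM, which sits with the values of compound 1 and compound 2 inside the usual scatter, so no order among the three can be drawn.

Compound 4 `O=c1[nH]cc(S(=O)(=O)Nc2ccc(-c3cn(-c4ccc(Cl)cc4)nn3)cc2)c(=O)[nH]1` is not yet measured. Relative to compound 3 it shows (4-chlorophenyl in place of 3-chlorophenyl on an aromatic nitrogen), the same change as that from compound 1 to compound 2, at a place described in the same words in both pairs. Because the step of a 1.2-fold higher number from compound 1 to compound 2 (0.08 log units; within the scatter) lay within the scatter, the step from compound 3 to compound 4 is expected to be of the same kind and size, a 1.2-fold higher number from compound 3 to compound 4 (0.07 log units; within the scatter), resting on a single measured example. For compound 4 in this assay the expected value is 2900 nM, with a plausible range from 1500 nM to 5500 nM.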

Compound 4, half-maximal inhibitory concentration: 1830 nM
The estimate for compound 4 lay 1.6-fold (0.20 log units) above the measured number; the measured number falls inside the stated range.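

In this assay, the exchange of 3-chlorophenyl for 4-chlorophenyl on an aromatic nitrogen gives a 1.3-fold lower number from compound 3 to compound 4 (0.13 log units; within the scatter), so on this second core the read-out also stays essentially where it was. Set beside the earlier step, the exchange behaves alike on the two cores, with no difference between them that can be read: the same change on two cores in this assay, a 1.2-fold higher number (0.08 log units; within the scatter) from compound 1 to compound 2 and a 1.3-fold lower number (0.13 log units; within the scatter) from compound 3 to compound 4, 1.6-fold (0.20 log units) apart, within the scatter of two such steps. Within the data shown here, this supports only a narrow statement, that moving the chlorine between these two named groups has no readable effect on either core; it gives no direction for the change, since the two steps are both within the scatter, and with only two pairs it does not show that a change with a larger effect would carry over between the cores in the same way.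

Open, as far as these compounds go, is whether replacing the chlorine with another substituent, such as methoxy, trifluoromethyl, a nitrile, an amine or a carboxylic acid, would move the read-out on either core, and whether any such step would be the same size on both. Also open, from the compounds shown here alone, is what an unsubstituted phenyl or a benzyl on the same aromatic nitrogen would give, and whether the flat picture holds in other cell lines.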